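A Difluorophenyl Replacement Tested on Cytotoxicity Data

This account rests on a few compounds, and the source may have more. Where it says the series, first, only, none or still open, it means among the compounds named here.

Compound 2 `CN(C)CCn1cnnc1-c1cc(Oc2ccc(NC(=O)N/N=C/c3ccc(O)c(Br)c3)cc2F)ccn1` gives 1860 nM in a functional assay on MKN-45 cells (Homo sapiens) for cytotoxicity, read by MTT assay, with a stated time of 72 h; on this read-out higher numbers stand for weaker inhibition and lower numbers for stronger inhibition. Among the three measured compounds it holds the second highest number: compound 1 `CN(C)CCn1cnnc1-c1cc(Oc2ccc(NC(=O)N/N=C/c3cccc(Br)c3)cc2F)ccn1` gives 450 nM, and compound 3 `Cn1cnnc1-c1cc(Oc2ccc(NC(=O)N/N=C/c3ccccc3)cc2F)ccn1` gives 7610 nM. Compound 4 `CN(C)CCn1cnnc1-c1cc(Oc2ccc(NC(=O)N/N=C/c3ccc(F)cc3F)cc2F)ccn1` differs from compound 2 by 2,4-difluorophenyl in place of 3-bromo-4-hydroxyphenyl on a carbon with a double bond to nitrogen. Going by the values given here, only one measured step bears on this change: a 4.1-fold higher number from compound 1 to compound 2 (0.62 log units; beyond the scatter), a modest step beyond the scatter that accompanied adding the hydroxy. Among the compounds with values here, because a 4.1-fold higher number from compound 1 to compound 2 (0.62 log units; beyond the scatter) went with the hydroxy entering, its removal in compound 4 is expected to bring the number down, while the exchange of bromine for two fluorines has no measured precedent here. Compound 4 is therefore expected to show a 3.1-fold lower number from compound 2 to compound 4 (0.49 log units; beyond the scatter). Compound 4 is estimated at 600 nM, with a range from 200 nM to 2000 nM.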

Compound 4, half-maximal inhibitory concentration: 810 nM
Compound 4: middle estimate off by 1.4-fold (0.13 log units), on the low side, within the range that was stated.
By their numbers in this assay, from the lowest: compounds 1 and 4 (each within the scatter of the next); then compound 2; then compound 3.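

In this assay the place on a carbon with a double bond to nitrogen accepts 2,4-difluorophenyl in place of 3-bromo-4-hydroxyphenyl, with a 2.3-fold lower number from compound 2 to compound 4 (0.36 log units; beyond the scatter) as the result, even though the entering group counts no hydrogen-bond donor. Set against 3-bromophenyl, the same group gives a 1.8-fold higher number from compound 1 to compound 4 (0.26 log units; within the scatter) here, so bromine is not needed for a number of this size among these compounds. On these data alone, whether a single fluorine, a methoxy group or an amine on the phenyl ring would give a similar number remains open. The data shown offer no measurement that explains either step.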